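The source may report more compounds than this note shows. Statements on the series, on what has been measured and on what is new or still open speak of the compounds shown alone.

Compound 1 `C#CC(C)OC(=O)c1ccc(C(CC)(CC)c2ccc(OCC(=O)C(C)(C)C)c(C)c2)n1CC` and compound 3 `C#CC(C)OC(=O)c1ccc(C(CC)(CC)c2ccc(OCC(O)C(C)(C)C)c(C)c2)n1CC` share most of their structure and differ only in one spot, namely (1-hydroxy-2,2-dimethylpropyl in place of (tert-butyl)carbonyl on a saturated chain carbon bound to an oxygen on an aromatic ring). In an assay on HL-60 cells for agonist activity at vitamin D3 receptor (Homo sapiens), read by microscopy, with a stated time of 96 h (a lower number here means that less compound is needed, a higher number that more compound is needed for the effect), compound 1 gives 210 nM, and compound 3 gives 200 nM; the step of a 1.1-fold lower number from compound 1 to compound 3 (0.02 log units; within the scatter) shows that this change in the core leaves the result essentially unchanged. Compound 2 `C#CCCOC(=O)c1ccc(C(CC)(CC)c2ccc(OCC(=O)C(C)(C)C)c(C)c2)n1CC` differs from compound 1 in another spot, (but-3-yn-1-yl in place of 1-methylprop-2-yn-1-yl on an oxygen next to a carbonyl group). Here the picture is very different: compound 2 gives 28800 nM in this assay, so the step of a 140-fold higher number from compound 1 to compound 2 (2.14 log units; beyond the scatter) is a large loss of potency.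

Compound 4 `C#CCCOC(=O)c1ccc(C(CC)(CC)c2ccc(OCC(O)C(C)(C)C)c(C)c2)n1CC` has not been measured. It relates to compound 3 exactly as compound 2 relates to compound 1, through (but-3-yn-1-yl in place of 1-methylprop-2-yn-1-yl on an oxygen next to a carbonyl group), the same change at the same place. Among the measured compounds shown here, since the cores of compound 1 and compound 3 behave alike, the expected step is a 140-fold higher number from compound 3 to compound 4 (2.15 log units; beyond the scatter), about as large as the one seen from compound 1 to compound 2. Compound 4 is therefore expected to give roughly 28000 nM in this assay, plausibly anywhere from 8000 nM to 100000 nM.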

Compound 4, half-maximal effective concentration: 1030 nM
Estimate against measurement, compound 4: 27-fold (1.43 log units) above; the measured number lies below the stated range.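

Once measured, the swap to but-3-yn-1-yl still raises the number in this assay, with a 5.2-fold higher number from compound 3 to compound 4 (0.71 log units; beyond the scatter), but its size does not carry over from the core of compound 1 to the core of compound 3: the same change on two cores in this assay, a 140-fold higher number (2.14 log units; beyond the scatter) from compound 1 to compound 2 and a 5.2-fold higher number (0.71 log units; beyond the scatter) from compound 3 to compound 4, 27-fold (1.43 log units) apart, beyond the scatter of two such steps. Seen from the other place in the molecule, changing (tert-butyl)carbonyl to 1-hydroxy-2,2-dimethylpropyl matters greatly when but-3-yn-1-yl is present, with a 28-fold lower number from compound 2 to compound 4 (1.45 log units; beyond the scatter), yet makes no real difference when 1-methylprop-2-yn-1-yl is present: the same change on two cores in this assay, a 1.1-fold lower number (0.02 log units; within the scatter) from compound 1 to compound 3 and a 28-fold lower number (1.45 log units; beyond the scatter) from compound 2 to compound 4, 27-fold (1.43 log units) apart, beyond the scatter of two such steps. So the two changes do not simply add up: on these two cores the direction of the swap held while its size did not, but a single set of four compounds neither explains this nor gives a rule for other cores.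

From the compounds shown here alone, it remains open whether other groups on that oxygen, such as a plain ethyl or a longer chain like pent-4-yn-1-yl, would show the same dependence on the core. Going by these compounds, it is also open how an amine in place of the hydroxy group would behave.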